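Amine substituent variation on the piperazine-bearing series

The compounds below may be only part of what the source reports. "The series", "measured", "known", "first", "only" and "open" are said of these compounds alone.

Compound 1 `Nc1ccccc1NC(=O)c1ccc(CSC(=S)N2CCN(c3ccccc3)CC2)cc1` and compound 2 `CN1CCN(C(=S)SCc2ccc(C(=O)Nc3ccccc3N)cc2)CC1` share one core and differ only at the amine nitrogen in the ring. In a functional assay on A-375 cells (Homo sapiens) for antiproliferative activity, read by CCK-8 assay, with a stated time of 72 h, tested at 8 uM (a higher number here means a stronger effect of the compound at the concentration tested, a lower number a weaker effect), compound 2 gives 91.6% and compound 1 gives 88.6%; the two numbers cannot be told apart, since a number 3 percentage points higher from compound 1 to compound 2 (within the scatter) stays inside the scatter. Compound 2 therefore stands level with compound 1 rather than apart from it.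

Compound 3 `Nc1ccccc1NC(=O)c1ccc(CSC(=S)N2CCN(C3CCCCC3)CC2)cc1` takes the same position further: cyclohexyl in place of methyl on an amine nitrogen in a ring. Going by the values given here, the one measured step at this position, methyl in place of phenyl, left the read-out unchanged beyond the scatter, so it is the only guide, and it argues against any shift when a cyclohexyl enters there. No movement beyond the scatter is expected in this assay for the change a number 2.6 percentage points lower from compound 2 to compound 3 (within the scatter).

Compound 3 is thus estimated at 89% in this assay, with a range from 78% to 96%.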

Compound 3, a percentage reported as inhibition, at one concentration (the size of the read-out at that concentration, not a potency): 89.9%
For compound 3 the middle estimate is 0.9 percentage points below the measured one; low and high end bracket the measured number.
By their numbers in this assay, from the lowest: compounds 1, 3 and 2 (each within the scatter of the next).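

Cyclohexyl for methyl gives a number 1.7 percentage points lower from compound 2 to compound 3 (within the scatter) and cyclohexyl for phenyl gives a number 1.3 percentage points higher from compound 1 to compound 3 (within the scatter) in this assay on the amine nitrogen in the ring. The earlier pair covered only methyl and phenyl; this position now also takes a non-aromatic ring of six carbons without a separation from either, so methyl, phenyl and cyclohexyl cannot be told apart at the one concentration tested. Nothing at hand explains why these three groups read alike.

As far as these compounds go, all three groups consist of carbon and hydrogen only, so it stays open whether a carboxylic acid, a primary amine or a longer chain ending in a hydroxyl group would move the read-out at this place. A concentration-response comparison of compound 1, compound 2 and compound 3 could also still separate them.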